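The compounds below may be only part of what the source reports. "The series", "measured", "known", "first", "only" and "open" are said of these compounds alone.

Measured compounds:
compound 1 `CCOc1ccc2nc(Cl)c(/C=N/NC(=O)c3cc4ccc(O)cc4oc3=O)cc2c1` gives 19200 nM
compound 2 `O=C(N/N=C/c1ccncc1)c1cc2cc(Br)ccc2oc1=O` gives 4890 nM
compound 3 `O=C(N/N=C/c1ccncc1)c1cc2ccccc2oc1=O` gives 17200 nM

All three were tested in a functional assay on HepG2 cells (Homo sapiens) for antiproliferative activity, read by fluorescence and resazurin assay, with a stated time of 48 h; on this read-out lower numbers stand for stronger inhibition and higher numbers for weaker inhibition. Compound 2 stands at the lowest number of the three in this assay, so it is the strongest inhibitor of this small set: compound 3 sits a step away at a 3.5-fold higher number from compound 2 to compound 3 (0.55 log units; beyond the scatter), and compound 1 sits further off still.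

The unmeasured compound 4 `O=C(N/N=C/c1cccnc1)c1cc2cc(Br)ccc2oc1=O` keeps the bromo group and the shared core of compound 2 and differs from it only in the ring that hangs from the carbon with a double bond to nitrogen: pyridin-3-yl in place of pyridin-4-yl on a carbon with a double bond to nitrogen.

Going by the values given here, none of the measured steps bears on this change. Among the compounds with values here, the only measured step, from compound 2 to compound 3, concerns hydrogen in place of bromo on an aromatic carbon and is modest; compound 1 differs from the others in several places at once and cannot be broken into single steps. There is therefore no direct guide for moving the ring nitrogen, and the expectation rests on the general experience that such a move often shifts the number only a little. For compound 4 a step of about a 1.3-fold higher number from compound 2 to compound 4 (0.12 log units; within the scatter) is expected, within or just beyond the scatter, toward a slightly weaker inhibition. Compound 4 is therefore estimated at 6500 nM, with a likely range from 2500 nM to 16000 nM.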

Compound 4, half-maximal inhibitory concentration: 19000 nM
Estimate against measurement, compound 4: 2.9-fold (0.47 log units) below, outside the stated range (above it).
By their numbers in this assay, from the lowest: compound 2; then compounds 3, 4 and 1 (each within the scatter of the next).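

In this assay, where the nitrogen sits in the ring clearly matters: with the bromo group and the shared core held fixed, pyridin-3-yl in place of pyridin-4-yl on a carbon with a double bond to nitrogen gives a 3.9-fold higher number from compound 2 to compound 4 (0.59 log units; beyond the scatter). Going by these compounds alone, the two rings have the same heavy atoms and the same counts of hydrogen-bond donors and acceptors, so a change that leaves those counts untouched can still move the number beyond the scatter, and the earlier compounds could not show this. Compound 2 now has two single-change neighbours, and the other one, with hydrogen in place of bromo, gives a 3.5-fold higher number from compound 2 to compound 3 (0.55 log units; beyond the scatter), so each of these two changes away from compound 2 leads to weaker inhibition, yet no measurement shown here explains why moving the ring nitrogen has this effect.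

The compounds shown leave open how pyridin-2-yl or a plain phenyl ring would behave at this place, since only two placements of the ring nitrogen can be read so far. They also leave open whether the same step would appear with hydrogen or methoxy in place of the bromo group.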